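From compound 3 to compound 4 on the chloro-phenyl amide

The source may report more compounds than this note shows. Statements on the series, on what has been measured and on what is new or still open speak of the compounds shown alone.

Three compounds share the acetoxy-biaryl amide core and differ only in the group on the amide nitrogen. In a functional assay on the whole organism (Ear) for inhibition, with Mus musculus as the target, at a dose of 40 mg/kg by the oral route (a higher number here means more inhibition at the dose given (going by the name of the read-out), a lower number less inhibition), compound 1 `CC(=O)Oc1ccc(-c2ccc(F)cc2F)cc1C(=O)Nc1ccccc1C` gives 19.6%, compound 2 `CC(=O)Oc1ccc(-c2ccc(F)cc2F)cc1C(=O)Nc1ccccc1Cl` gives 41.4%, and compound 3 `CC(=O)Oc1ccc(-c2ccc(F)cc2F)cc1C(=O)Nc1ccc(Cl)cc1` gives 0%. Compound 3 thus stands lowest of the three; compound 1 lies closest to it and compound 2 furthest, with a number 19.6 percentage points lower from compound 1 to compound 3 (beyond the scatter) and a number 41.4 percentage points lower from compound 2 to compound 3 (beyond the scatter).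

Compound 4 `CC(=O)Oc1ccc(-c2ccc(F)cc2F)cc1C(=O)NN1CCOCC1` carries the change (morpholin-4-yl in place of 4-chlorophenyl on an amide-type nitrogen). Among the measured steps, the two that reach compound 3 are the ones that bear on this change: both replace a 2-substituted phenyl by 4-chlorophenyl on the amide nitrogen, and both lowered the number, one modestly and one largely. For the measured compounds named here, no measured step puts a non-aromatic ring, or a second nitrogen, on the amide nitrogen, so there is no direct precedent for the morpholin-4-yl group. With compound 3 already at zero, the number cannot fall further; the plausible outcomes are no change beyond the scatter or a modest rise. Compound 4 is therefore expected to give about 12%, within 0% to 35%, which means an estimated step of a number 12 percentage points higher from compound 3 to compound 4 (beyond the scatter).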

Compound 4, a percentage reported as inhibition, in the whole organism at one dose (the size of the read-out at that dose, not a potency): 0%
Estimate against measurement, compound 4: 12 percentage points above, within the range that was stated.
By their numbers in this assay, from the lowest: compounds 3 and 4 (each within the scatter of the next); then compound 1; then compound 2.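

In this assay, for the compounds shown here, the first group on the amide-type nitrogen without an aromatic ring, morpholin-4-yl, gave no change at the digits printed from compound 3 to compound 4 (within the scatter), so replacing 4-chlorophenyl with this non-aromatic ring bearing two hetero atoms produced no measurable recovery. The other two steps, a number 41.4 percentage points lower from compound 2 to compound 4 (beyond the scatter) and a number 19.6 percentage points lower from compound 1 to compound 4 (beyond the scatter), match those already seen for 4-chlorophenyl, and among these four compounds only those with 2-chlorophenyl or 2-methylphenyl on this nitrogen give a reading above zero, with no compound going against that pattern. No evidence on hand accounts for this result.

Going by these compounds, with compound 3 and compound 4 both reading zero, this single dose cannot separate 4-chlorophenyl from morpholin-4-yl, so any difference between them that lies below the reach of the read-out remains unknown. The compounds shown also leave open how a plain phenyl, a cyclohexyl or a pyridyl group on the amide-type nitrogen would read, and so whether the reading depends on the substituted phenyl ring itself or on the place of its substituent.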